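Nitro for Methoxy on Two Chalcone Cores

The source may hold more compounds than are shown below. What is called first, only, known or untested is meant among the compounds shown, and "the series" means these compounds.

Compound 1 `C#CCOc1ccc(/C=C/C(=O)c2ccc(OC)cc2)cc1` and compound 2 `C#CCOc1ccc(/C=C/C(=O)c2ccc([N+](=O)[O-])cc2)cc1` share one core and differ only by nitro in place of methoxy on an aromatic carbon. In a functional assay on MIA PaCa-2 cells (Homo sapiens) for inhibition, read by MTT assay, with a stated time of 48 h, tested at 10 uM (a higher number here means more inhibition of growth at the concentration tested, a lower number less inhibition of growth), compound 1 gives 32%, while compound 2 gives 42%; the step reads a number 10 percentage points higher from compound 1 to compound 2 (within the scatter). Compound 3 `COc1ccc(C(=O)/C=C/c2ccc(OCc3cn(Cc4ccccc4)nn3)cc2)cc1` rests on another core, and the difference between the two cores is not broken down here. In this assay compound 3 gives 68%, the highest of the three. Compound 4 `O=C(/C=C/c1ccc(OCc2cn(Cc3ccccc3)nn2)cc1)c1ccc([N+](=O)[O-])cc1` has not been measured; it differs from compound 3 by nitro in place of methoxy on an aromatic carbon, which is the same change as that between compound 1 and compound 2. In this assay the expected step is a number 7 percentage points higher from compound 3 to compound 4 (within the scatter), since the same change earlier gave a number 10 percentage points higher from compound 1 to compound 2 (within the scatter). Compound 4 is accordingly expected to give 75%, with a likely range from 60% to 88%.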

Compound 4, percent growth inhibition at one concentration: "not active" (no number reported)
Nothing numeric was reported for compound 4; there is nothing to compare the estimate with.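

Among these compounds, compound 4 is reported in this assay as not active, without a number, so no step from compound 3 to compound 4 can be read. The compounds shown leave open whether nitro in place of methoxy has the same size of effect on both cores. Nothing given here bears on this result.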